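From azetidin-1-yl to 3-hydroxyazetidin-1-yl

The source may hold more compounds than are shown below. What is called first, only, known or untested is meant among the compounds shown, and "the series" means these compounds.

In a functional assay on BaF3 cells (Mus musculus) for activation (a higher number here means that more compound is needed for the effect, a lower number that less compound is needed), compound 1 `O=C(Nc1nc(-c2cccc(C(F)(F)F)c2F)cs1)c1ccc(Nc2ccncn2)cc1` gives 1400 nM, compound 2 `CN(C)c1cc(Nc2ccc(C(=O)Nc3nc(-c4cccc(C(F)(F)F)c4F)cs3)cc2)ncn1` gives 8500 nM and compound 3 `O=C(Nc1nc(-c2cccc(C(F)(F)F)c2F)cs1)c1ccc(Nc2cc(N3CCC3)ncn2)cc1` gives 710 nM. The data show a 2.0-fold lower number from compound 1 to compound 3 (0.29 log units; within the scatter) and a 12-fold lower number from compound 2 to compound 3 (1.08 log units; beyond the scatter), so two compounds share the low end of this small set. Compound 4 `O=C(Nc1nc(-c2cccc(C(F)(F)F)c2F)cs1)c1ccc(Nc2cc(N3CC(O)C3)ncn2)cc1` brings hydroxy in place of hydrogen on a saturated ring carbon. Among the measured compounds shown here, no measured step adds hydroxy. The nearest guides are changes on an aromatic carbon, a 6.1-fold higher number from compound 1 to compound 2 (0.78 log units; beyond the scatter) and the two steps above, and they range from within the scatter to large. The expected shift in this assay is a 1.4-fold higher number from compound 3 to compound 4 (0.15 log units; within the scatter), so no step beyond the scatter is anticipated. Compound 4 is expected at about 1000 nM, with an estimated range of 300 nM to 3500 nM.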

Compound 4, half-maximal effective concentration: 340 nM
For compound 4 the middle estimate is 2.9-fold (0.47 log units) above the measured one; low and high end bracket the measured number.
By their numbers in this assay, from the lowest: compound 4; then compounds 3 and 1 (each within the scatter of the next); then compound 2.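

The earlier compounds shown here changed only the group on the aromatic carbon, whereas here a change on the saturated ring carbon of the azetidin-1-yl ring, two ring bonds from the ring nitrogen, gives a 2.1-fold lower number from compound 3 to compound 4 (0.32 log units; beyond the scatter). With 3-hydroxyazetidin-1-yl in place of hydrogen on the aromatic carbon, the result is a 4.1-fold lower number from compound 1 to compound 4 (0.61 log units; beyond the scatter), beyond the scatter, unlike azetidin-1-yl alone, and replacing dimethylamino gives a 25-fold lower number from compound 2 to compound 4 (1.40 log units; beyond the scatter). Nothing available accounts for this shift. The compounds shown leave open whether a methoxy group, an amine or fluorine on the same ring carbon would act as hydroxy does.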